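The source may report more compounds than this note shows. Statements on the series, on what has been measured and on what is new or still open speak of the compounds shown alone.

Measured so far:
compound 1 `Cc1ccc(NC2=NCCO2)cc1` gives 22000 nM
compound 2 `O=C(CCl)NC(=O)Nc1ccc(-c2ccccc2)cc1` gives 1400 nM

In a functional assay on M21 cells (Homo sapiens) for inhibition, read by sulforhodamine B assay, with a stated time of 48 h (a higher number here means a weaker inhibitor of growth, a lower number a stronger inhibitor of growth), compound 2 gives 1400 nM, the lower of the two numbers. Compound 1 gives 22000 nM, and the gap between the two numbers lies beyond the scatter. Compound 3 `O=C(CCl)NC(=O)Nc1ccc(Oc2ccccc2)cc1` has phenoxy in place of phenyl on an aromatic carbon. Among the measured compounds shown here, no measured pair shows a change of this kind, so the expectation is weakly grounded: no step beyond the scatter in this assay, with only a slight lean towards a higher number. The expected step is a 1.4-fold higher number from compound 2 to compound 3 (0.15 log units; within the scatter). For compound 3 the estimate is 2000 nM, with an expected range from 700 nM to 6000 nM.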

Compound 3, concentration for 50% growth inhibition: 4200 nM
Compound 3: the middle estimate sits 2.1-fold (0.32 log units) below what was measured; the range from low to high includes it.
By their numbers in this assay, from the lowest: compound 2; then compound 3; then compound 1.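

In this assay, phenoxy in place of phenyl on the aromatic carbon, para to a group of 8 heavy atoms, gives a 3.0-fold higher number from compound 2 to compound 3 (0.48 log units; beyond the scatter). This first step at the position shows that it is not indifferent to the change: the six-membered aromatic ring stays, and the entering group adds one oxygen and one hydrogen-bond acceptor. No measurement shown gives a cause for the step. Open, from the compounds shown here alone, is how an amine or methylene link in place of the phenoxy oxygen would read here. Also open, going by these compounds, is how a methoxy group, which carries no ring, would compare with phenyl and phenoxy.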